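The compounds below may be only part of what the source reports. "The series", "measured", "known", "first", "only" and "open" are said of these compounds alone.

Among the compounds with values here, in an ADME assay on L6 cells (Rattus norvegicus) for cytotoxicity, read by resazurin assay, with a stated time of 70 h (on this read-out higher numbers stand for weaker inhibition and lower numbers for stronger inhibition), three compounds that share one core have numbers so far. Compound 1 `CC1=CC(C)(C)N(Cc2ccc(Cl)cc2)c2ccc(O)cc21` gives 7900 nM, compound 2 `CC(=O)Oc1ccc2c(c1)C(C)=CC(C)(C)N2Cc1ccc(Cl)cc1` gives 22000 nM, and compound 3 `COc1cccc(CN2c3ccc(OC(C)=O)cc3C(C)=CC2(C)C)c1` gives 29000 nM. Compound 2 therefore stands level with compound 3 within the scatter, and both sit clearly on the weaker side of compound 1.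

The next compound is compound 4 `CC(=O)Oc1ccc2c(c1)C(C)=CC(C)(C)N2C(C)=O`. It has acetyl in place of 4-chlorobenzyl on a nitrogen on an aromatic ring in a ring, and the change counts as acetyl in place of 4-chlorobenzyl on a nitrogen on an aromatic ring in a ring.

Within the data shown here, two measured steps bear on this change, both only indirectly. Putting acetyl in place of hydrogen on an oxygen gave a 2.8-fold higher number from compound 1 to compound 2 (0.44 log units; beyond the scatter), a modest step, but at a different place in the molecule. Putting 3-methoxyphenyl in place of 4-chlorophenyl gave a 1.3-fold higher number from compound 2 to compound 3 (0.12 log units; within the scatter), so that swap left the number within the scatter. Neither step removes the aromatic ring from the nitrogen substituent, so the data offer no direct guide to this change. A modest step towards a higher number, meaning weaker inhibition, is a cautious expectation.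

For compound 4 the expected value is 60000 nM, with an estimated range from 20000 nM to 180000 nM. This estimate corresponds to an expected 2.7-fold higher number from compound 2 to compound 4 (0.44 log units; beyond the scatter).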

Compound 4, half-maximal inhibitory concentration: 160000 nM
Estimate against measurement, compound 4: 2.7-fold (0.43 log units) below; low and high end bracket the measured number.
By their numbers in this assay, from the lowest: compound 1; then compounds 2 and 3 (each within the scatter of the next); then compound 4.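

In this assay, the nitrogen of the shared core proves sensitive to what it carries: replacing 4-chlorobenzyl with acetyl gives a 7.3-fold higher number from compound 2 to compound 4 (0.86 log units; beyond the scatter), a larger step than either earlier one. The earlier change on this substituent, a 1.3-fold higher number from compound 2 to compound 3 (0.12 log units; within the scatter), altered only the groups on its aromatic ring and stayed within the scatter, whereas this one removes that ring altogether and moves the number towards weaker inhibition. No measurement shown here accounts for this shift.

The exchange changes several things at once: the substituent falls from 8 heavy atoms to 3, loses its aromatic ring and gains a carbonyl with one hydrogen-bond acceptor, so these compounds cannot show which of these differences matters. As far as these compounds go, a benzoyl group on the same nitrogen would keep both the aromatic ring and the carbonyl, while an ethyl chain would have neither, and the effect of either group in this assay remains open.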